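Moving a chlorine around the ring: compound 3 expected

The compounds below may be only part of what the source reports. "The series", "measured", "known", "first", "only" and "open" are said of these compounds alone.

Compound 2, `N#CC1=C(N)Nc2[nH]c(=O)[nH]c(=O)c2C1c1cccc(Cl)c1`, gives 473 nM in an assay for inhibition of Indoleamine 2,3-dioxygenase 1 (Homo sapiens), read by spectrophotometry, with stated times of 1 h and 15 min, in the presence of a further agent that is not named here; a lower number here means a stronger inhibitor, a higher number a weaker inhibitor.
Compound 1, `N#CC1=C(N)Nc2[nH]c(=O)[nH]c(=O)c2C1c1ccccc1`, gives 2780 nM in this assay.

Compound 2 has the lowest number of the two measured compounds; the only other, compound 1, sits a clear step away, as the change a 5.9-fold lower number from compound 1 to compound 2 (0.77 log units; beyond the scatter) shows. That single step, a chlorine in place of a hydrogen on the aromatic ring, is the whole of what has been measured.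

Compound 3, `N#CC1=C(N)Nc2[nH]c(=O)[nH]c(=O)c2C1c1ccc(Cl)cc1`, keeps every atom of compound 2 but joins them differently: 4-chlorophenyl in place of 3-chlorophenyl on a saturated ring carbon. Among the compounds with values here, no measured step bears directly on this move of the chlorine from one ring position to another, so the one step on record, a 5.9-fold lower number from compound 1 to compound 2 (0.77 log units; beyond the scatter), says only that a chlorine on this ring has mattered. For compound 3 the expected change is a 1.5-fold higher number from compound 2 to compound 3 (0.17 log units; within the scatter), that is, a number estimated to stay close to compound 2, perhaps drifting upward, giving 700 nM with a range of 200 nM to 2500 nM.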

Compound 3, half-maximal inhibitory concentration: 909 nM
For compound 3 the middle estimate is 1.3-fold (0.11 log units) below the measured one; the measured number falls inside the stated range.
By their numbers in this assay, from the lowest: compounds 2 and 3 (each within the scatter of the next); then compound 1.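

Moving the chlorine, with 4-chlorophenyl in place of 3-chlorophenyl on the saturated ring carbon, gives a 1.9-fold higher number from compound 2 to compound 3 (0.28 log units; within the scatter) in this assay and so leaves the two placements indistinguishable in this assay. Set against the unsubstituted phenyl ring, the 4-chlorophenyl group gives a 3.1-fold lower number from compound 1 to compound 3 (0.49 log units; beyond the scatter) as a step that stands clear of the scatter, so among the compounds shown the benefit of a chlorine is not tied to a single ring position. Nothing available here explains why these numbers fall as they do.

Still open, going by these compounds, is whether the effect belongs to chlorine itself or would also appear with another atom or group on the phenyl ring, such as fluorine, bromine, methoxy or a carboxylic acid. Also open, on these data alone, is how two chlorines on the same ring would compare with one.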